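This account rests on a few compounds, and the source may have more. Where it says the series, first, only, none or still open, it means among the compounds named here.

The study measures an ADME assay on Raji cells (Homo sapiens) for cytotoxicity, with a stated time of 72 h; a lower number here means that less compound is needed, a higher number that more compound is needed for the effect. Compound 1, with the structure `Cc1ccc(-c2nc3ccccc3s2)cc1NC(=O)c1cc([N+](=O)[O-])c(N2CCCCC2)cc1Cl`, sits at a limit of this assay: in this assay compound 1 gives > 25000 nM, which is a boundary of the measurement and not a number. A second compound, compound 2, with the structure `Cc1cc(NC(=O)c2cc([N+](=O)[O-])ccc2Cl)cc(-c2nc3ccccc3o2)c1O`, also sits at a limit: in this assay compound 2 gives > 25000 nM. Both values shown thus rest on (the limit of > 25000 nM in this assay, at which 2 of the 2 values shown sit), so compound 1 and compound 2 cannot be told apart on these numbers.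

Compound 3, with the structure `COC(=O)C1CCN(c2cc(Cl)c(C(=O)Nc3cc(-c4nc5ccccc5s4)ccc3C)cc2[N+](=O)[O-])CC1`, has not yet been measured. It differs from compound 1 in one place: methoxycarbonyl in place of hydrogen on a saturated ring carbon. Among the measured compounds shown here, no measured step between compounds of this study is available, and because the only values at hand are the limit of > 25000 nM in this assay, at which 2 of the 2 values shown sit, there is nothing to suggest that a small addition on the saturated ring would move the result into the measurable range. For compound 3 the expected step is a step that the limit leaves unreadable from compound 1 to compound 3, none beyond the scatter. Compound 3 is therefore estimated at 40000 nM, with a range from 15000 nM to 150000 nM, most likely again reported only as a limit.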

Compound 3, half-maximal effective concentration: > 25000 nM
Compound 3: no number, only a limit (the forecaster's own chance of this, stated with the estimate: 85%); the middle value is on the limit's open side.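

Among the compounds shown here, compound 3, like compound 1, gives only a limit in this assay, and no step between the two can be read from these results: the limit of > 25000 nM in this assay, at which 3 of the 3 values shown sit. The compounds shown leave open how much compound any of them would need for the effect, and whether any change to these structures would give a measurable value in this assay.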